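Benzenesulfonyl piperidine amides: a bicyclic aryl replacement

The compounds below may be only part of what the source reports. "The series", "measured", "known", "first", "only" and "open" are said of these compounds alone.

Compound 1 `CCN(Cc1ccccc1)C(=O)C1CCN(S(=O)(=O)c2ccccc2OC)CC1` has only a limit in a functional assay on CHO cells for positive allosteric modulation of muscarinic acetylcholine receptor M5 (Homo sapiens), read by calcium flux (on this read-out higher numbers stand for an effect only at larger amounts of compound and lower numbers for an effect already at smaller amounts), where compound 1 gives > 10000 nM. Compound 2 `CCN(Cc1ccccc1)C(=O)C1CCN(S(=O)(=O)c2ccc3cccnc3c2)CC1` likewise reaches only the limit, compound 2 giving > 10000 nM; > 10000 nM (2 entries). Compound 3 `CCN(Cc1ccccc1)C(=O)C1CCN(S(=O)(=O)c2ccc3[nH]ncc3c2)CC1` gives a number in this assay, compound 3 showing 1550 nM; 1600 nM (2 entries), with its repeat entries agreeing (the several entries of compound 3 in this assay, 1550 nM; 1600 nM (2 entries)). The limit of the assay thus marks two of the three values shown (the limit of > 10000 nM in this assay, at which 1 of the 3 values shown sits). Compound 4 `CCN(Cc1ccccc1)C(=O)C1CCN(S(=O)(=O)c2cccc3nsnc23)CC1` carries a group of 9 heavy atoms (6 carbon, 2 nitrogen, 1 sulfur; one five-membered aromatic ring with 3 hetero atoms, one six-membered aromatic ring of carbon only) in place of a group of 8 heavy atoms (7 carbon, 1 oxygen; one six-membered aromatic ring of carbon only), on a sulfonyl sulfur. Among the compounds with values here, no measured pair shows this change, so the expected step rests only on compound 3 having a number where compound 1 has a limit. Compound 4 is expected at 3500 nM, within 1200 nM to 10000 nM. The estimated step is an at least 2.8-fold lower number from compound 1 to compound 4 (0.45 log units; beyond the scatter).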

Compound 4, half-maximal effective concentration: > 10000 nM
Compound 4: no number, only a limit; the forecaster's own chance of this, stated with the estimate: 40%; middle value at least 2.8-fold (0.45 log units) away from the limit.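

In this assay compound 4 gives > 10000 nM, a limit and not a number. Within the data shown here, compound 1 also has only a limit, so no step from compound 1 to compound 4 can be read. As far as these compounds go, how far either compound lies beyond its limit remains open.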